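This account rests on a few compounds, and the source may have more. Where it says the series, first, only, none or still open, it means among the compounds named here.

The compounds measured so far, in an assay on FRT cells for positive allosteric modulation of Cystic fibrosis transmembrane conductance regulator variant N1303K (Homo sapiens), in the presence of a further agent that is not named here; a lower number here means that less compound is needed, a higher number that more compound is needed for the effect:

Compound 1 `COc1ccc2[nH]c3c(c2c1)CCNC31CCN(Cc2ccc(F)c(Cl)c2F)CC1` gives 4500 nM.
Compound 2 `COc1ccc2[nH]c3c(c2c1)CCNC31CCN(Cc2ccc(F)cc2F)CC1` gives 2000 nM.
Compound 3 `COc1ccc2[nH]c3c(c2c1)CCNC31CCN(Cc2cc(F)c(F)cc2F)CC1` gives 600 nM.

Compound 2 stands second of the three numbers in this assay: it sits below compound 1 by a 2.3-fold lower number from compound 1 to compound 2 (0.35 log units; beyond the scatter), and above compound 3 by a 3.3-fold lower number from compound 2 to compound 3 (0.52 log units; beyond the scatter). The whole spread among these three is set by the change of a 7.5-fold lower number from compound 1 to compound 3 (0.88 log units; beyond the scatter), and every one of these steps alters only the halogen pattern on the benzyl group attached to the piperidine nitrogen.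

Compound 4 `Fc1ccc(CN2CCC3(CC2)NCCc2c3[nH]c3ccc(Br)cc23)c(F)c1` is not yet measured. It differs from compound 2 in another part of the molecule: bromo in place of methoxy on an aromatic carbon. For the measured compounds named here, no measured step touches this aromatic carbon of the fused core, so the three known steps give no direct guide to the direction or size of the change. Going by the values given here, they show only that modest changes of halogen substitution elsewhere move this assay by amounts beyond the scatter. Without a comparable step at this position, the expectation for compound 4 is a step of no change at the digits printed from compound 2 to compound 4 (within the scatter), that is, none beyond the scatter, with a wide band of uncertainty. Compound 4 is therefore estimated to give 2000 nM in this assay, within a range from 600 nM to 7000 nM.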

Compound 4, half-maximal effective concentration: 21000 nM
Estimate against measurement, compound 4: 11-fold (1.02 log units) below; the measured number lies above the stated range.
By their numbers in this assay, from the lowest: compound 3; then compound 2; then compound 1; then compound 4.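

In this assay the change to the shared core gives an 11-fold higher number from compound 2 to compound 4 (1.02 log units; beyond the scatter) and is printed as a large step, whereas each halogen change on the benzyl group is printed as modest. This aromatic carbon, meta to a fused ring and para to a fused ring, therefore matters to this read-out: with the benzyl group of compound 2 kept unchanged, replacing methoxy with bromo alone means that considerably more compound is needed for the effect. The data shown offer nothing that accounts for this step.

For the compounds shown here, with only this one exchange at this carbon, the compounds leave open whether the step reflects the departure of methoxy or the arrival of bromo, a question that a hydrogen, a hydroxy, an ethoxy or an amine at the same carbon could help to separate. Going by these compounds, it also remains open whether the same exchange would move the number as far when the benzyl group carries the 2,4,5-trifluorophenyl pattern of compound 3.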